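The source may report more compounds than this note shows. Statements on the series, on what has been measured and on what is new or still open speak of the compounds shown alone.

Measured so far:
compound 1, `O=C(NCc1ccco1)c1cccc(O)c1O`: > 40000 nM, a limit of the assay.
compound 2, `O=C(NCC1CCCCC1)c1cccc(O)c1O`: 21000 nM.

All values come from an ADME assay on NCI-H630 cells (Homo sapiens) for cytotoxicity, read by MTT assay, with a stated time of 72 h; on this read-out lower numbers stand for higher toxicity in this test and higher numbers for lower toxicity in this test. For compound 1 the value is a limit only; it sits at the limit of > 40000 nM in this assay, at which 1 of the 2 values shown sits. Within the data shown here, compound 2 thus stands as the only number in this set, the one other value being a limit. Among the measured compounds shown here, the single step within the measured pair is an at least 1.9-fold lower number from compound 1 to compound 2 (0.27 log units; that floor lies within the scatter), with cyclohexyl in place of furan-2-yl on a saturated chain carbon bound to an amide-type nitrogen; as one end is a limit, this step is only a floor and lies within the scatter.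

Compound 3, `O=C(NCC1CCCCC1)c1cc(S(=O)(=O)N2CCCCC2)cc(O)c1O`, is not yet measured. It differs from compound 2 by (piperidin-1-yl)sulfonyl in place of hydrogen on an aromatic carbon. For the measured compounds named here, no measured step touches the aromatic ring; the one known step alters the group on the amide side and carries no information on this change. No step beyond the scatter is therefore expected in this assay, and the estimate rests on compound 2 alone. The expected step is no change at the digits printed from compound 2 to compound 3 (within the scatter). For compound 3 the estimated value is 21000 nM, with a range from 7000 nM to 60000 nM.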

Compound 3, half-maximal cytotoxic concentration: > 40000 nM
Compound 3 ended at the assay's limit (the forecaster's own chance of this, stated with the estimate: 30%); at least 1.9-fold (0.27 log units) between middle value and limit.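

Working notes on the ring position: this is the first reading in the series on a change to the aromatic ring rather than the amide side. In this assay, (piperidin-1-yl)sulfonyl on the aromatic carbon para to a hydroxy group gives an at least 1.9-fold higher number from compound 2 to compound 3 (0.27 log units; that floor lies within the scatter), and this step is a floor only. Compound 3 gives > 40000 nM, which is a limit of the assay. The new information is that this aromatic carbon carries a group with a six-membered non-aromatic ring with no lower number in this test, and compound 3 sits with compound 1 at the same limit: the limit of > 40000 nM in this assay, at which 2 of the 3 values shown sit.

The true size of the step stays unread, and the compounds shown do not separate the contribution of the sulfonyl link from that of the piperidine ring. Open too, going by these compounds, is how a morpholin-4-ylsulfonyl group, a dimethylaminosulfonyl group or a carboxylic acid would read on this aromatic carbon, and whether the reading carries over to the furan-2-yl amide side of compound 1.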